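Methyl on the core: compound 2 to compound 4

This account rests on a few compounds, and the source may have more. Where it says the series, first, only, none or still open, it means among the compounds named here.

Working notes on a set of uracil-ether acids and anilines. Compound 1 is `O=C(O)c1ccc(OCCCCCn2ccc(=O)[nH]c2=O)cc1`. In an ADME assay on HEL cells (Homo sapiens) for cytotoxicity, read by microscopy (on this read-out lower numbers stand for higher toxicity in this test and higher numbers for lower toxicity in this test), compound 1 gives > 100000 nM, which is a limit of the assay and not a number. Compound 3 is `Nc1ccc(OCCCCCn2ccc(=O)[nH]c2=O)cc1`, and in this assay compound 3 gives > 100000 nM, again a limit. For the measured compounds named here, compound 2 is `O=c1ccn(CCCCCOc2ccc(Br)cc2)c(=O)[nH]1`; in this assay compound 2 gives 100000 nM, the only number in the set, the other two values sitting at the limit of > 100000 nM in this assay, at which 2 of the 3 values shown sit. The steps of a number no higher from compound 1 to compound 2 (the limit leaves the size open), a number no lower from compound 2 to compound 3 (the limit leaves the size open) and a step that the two limits leave unreadable from compound 1 to compound 3 are therefore unreadable in size. Compound 4 is `Cc1cn(CCCCCOc2ccc(Br)cc2)c(=O)[nH]c1=O`; it differs from compound 2 by methyl in place of hydrogen on an aromatic carbon. Going by the values given here, no measured step touches this position, so no step beyond the scatter is expected: no change at the digits printed from compound 2 to compound 4 (within the scatter). Compound 4 is estimated at 100000 nM, within 50000 nM to 200000 nM.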

Compound 4, minimum cytotoxic concentration: 100000 nM
Compound 4: middle estimate and measured number agree at the digits printed, within the range that was stated.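

In this assay, for the compounds shown here, methyl in place of hydrogen on an aromatic carbon of the six-membered aromatic ring with 2 nitrogen gives no change at the digits printed from compound 2 to compound 4 (within the scatter), the only step that can be read. Going by these compounds alone, this is the first reading at this position, and it holds for the bromo compounds only. The other steps cannot be read, and the values behind them are limits: the limit of > 100000 nM in this assay, at which 2 of the 4 values shown sit.

As far as these compounds go, whether ethyl or an amine at this aromatic carbon would read the same remains open. So does the effect of a longer chain on the ring nitrogen.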